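The source may hold more compounds than are shown below. What is called first, only, known or untested is meant among the compounds shown, and "the series" means these compounds.

Three compounds share one core and differ only in the group carried on the outer aromatic ring. Compound 1 `Cc1ccccc1-c1ccc(CN2C(=O)[C@H](NC(=O)CC(C)(C)N)CCc3ccccc32)cc1` bears a methyl there and in a functional assay (Pituitary gland cell) with Rattus norvegicus as the target (a lower number here means that less compound is needed, a higher number that more compound is needed for the effect), compound 1 gives 1 uM. Compound 2 `COC(=O)c1ccccc1-c1ccc(CN2C(=O)[C@H](NC(=O)CC(C)(C)N)CCc3ccccc32)cc1` bears a methoxycarbonyl in its place, and compound 2 gives 2 uM; the step is a 2.0-fold higher number from compound 1 to compound 2 (0.30 log units; within the scatter). For the measured compounds named here, compound 3 `Cn1nnnc1-c1ccccc1-c1ccc(CN2C(=O)[C@H](NC(=O)CC(C)(C)N)CCc3ccccc32)cc1` bears a 1-methyl-1H-tetrazol-5-yl, and compound 3 gives 0.5 uM, the lowest of the three numbers; against compound 1 the step is a 2.0-fold lower number from compound 1 to compound 3 (0.30 log units; within the scatter), against compound 2 it is a 4.0-fold lower number from compound 2 to compound 3 (0.60 log units; beyond the scatter), the only step here that goes beyond the scatter.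

Compound 4 `CC(C)(N)CC(=O)N[C@@H]1CCc2ccccc2N(Cc2ccc(-c3ccccc3C#N)cc2)C1=O` is not yet measured. Its change from compound 3 is cyano in place of 1-methyl-1H-tetrazol-5-yl on an aromatic carbon. Going by the values given here, no measured step involves a cyano, so the expectation rests on the three steps above, which span from within the scatter up to a modest change. The cyano is smaller than the group it replaces, closer in size to the methyl of compound 1, and compound 1 sits within the scatter of compound 3. The step from compound 3 to compound 4 is therefore expected to be small, a 2.0-fold higher number from compound 3 to compound 4 (0.30 log units; within the scatter), in the direction of a higher number but not beyond the scatter. The estimate for compound 4 in this assay is 1 uM, with a range from 0.4 uM to 2.5 uM.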

Compound 4, concentration for half-maximal effect: 5 uM
Estimate against measurement, compound 4: 5.0-fold (0.70 log units) below, and the stated range ends below it.
By their numbers in this assay, from the lowest: compounds 3, 1 and 2 (each within the scatter of the next, the first and the last beyond it); then compound 4.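

In this assay the cyano on this aromatic carbon, ortho to a large group, gives the highest number of the four compounds, with a 10-fold higher number from compound 3 to compound 4 (1.00 log units; beyond the scatter) and a 2.5-fold higher number from compound 2 to compound 4 (0.40 log units; beyond the scatter) and also a 5.0-fold higher number from compound 1 to compound 4 (0.70 log units; beyond the scatter) and with every one of these steps beyond the scatter. For the compounds shown here, the methyl, methoxycarbonyl and 1-methyl-1H-tetrazol-5-yl had left only one step beyond the scatter, whereas the cyano now shows that this position can separate groups more widely, and the count of heavy atoms does not order them, since the cyano, with 2 heavy atoms, stands apart from both the small methyl of compound 1 and the 1-methyl-1H-tetrazol-5-yl, with 6 heavy atoms. Nothing available here explains why the cyano stands apart from the other three groups.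

As far as these compounds go, whether a chlorine atom or a hydroxyl on this carbon would read like the cyano or like the methyl remains open, as does the place of a carboxylic acid or an amine there. From the compounds shown here alone, all four compounds share one core and are compared in a single assay, so whether this order holds on another core or in another read-out also remains open.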